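A Methylcarbamoyl Group in Place of Trifluoromethoxy

The compounds below may be only part of what the source reports. "The series", "measured", "known", "first", "only" and "open" are said of these compounds alone.

Three compounds sharing one core have been measured in an assay on CHO-TREX cells for antagonist activity at transient receptor potential cation channel subfamily A member 1 (Homo sapiens), read by FLIPR and calcium flux, with a stated time of 10 min; on this read-out lower numbers stand for stronger inhibition and higher numbers for weaker inhibition:

compound 1, `FC(F)(F)c1ccccc1-c1ccc2[nH]ncc2c1`, gives 164 nM
compound 2, `CCc1cc2[nH]ncc2cc1-c1ccccc1C(F)(F)F`, gives 50 nM
compound 3, `FC(F)(F)Oc1cc2[nH]ncc2cc1-c1ccccc1C(F)(F)F`, gives 36 nM

Compound 3 has the lowest number of the three in this assay, but its gap to compound 2 is within the scatter, so the two cannot be ordered; only compound 1 stands clearly apart, as the step of a 4.6-fold lower number from compound 1 to compound 3 (0.66 log units; beyond the scatter) shows.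

Compound 4, `CNC(=O)c1cc2[nH]ncc2cc1-c1ccccc1C(F)(F)F`, differs from compound 3 in one place: methylcarbamoyl in place of trifluoromethoxy on an aromatic carbon.

Among the measured compounds shown here, no measured step exchanges a group of this kind. The nearest comparisons are a 3.3-fold lower number from compound 1 to compound 2 (0.52 log units; beyond the scatter) and a 4.6-fold lower number from compound 1 to compound 3 (0.66 log units; beyond the scatter), both placing a group where compound 1 has hydrogen, and a 1.4-fold lower number from compound 2 to compound 3 (0.14 log units; within the scatter), which swaps one such group for another. Those steps say only that filling this position has so far helped modestly; they say nothing about a methylcarbamoyl group, which brings a hydrogen-bond donor that neither ethyl nor trifluoromethoxy has. The expectation for compound 4 is therefore wide: the number is expected to fall somewhere between compound 1 and compound 3, and compound 4 is estimated at 100 nM (range 25 nM to 400 nM), a step of a 2.8-fold higher number from compound 3 to compound 4 (0.44 log units; beyond the scatter) that is expected to be a modest rise.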

Compound 4, half-maximal inhibitory concentration: > 30000 nM
Compound 4 ended at the assay's limit; the forecaster's own chance of this, stated with the estimate: 5%; at least 300-fold (2.47 log units) between middle value and limit.
By their numbers in this assay, from the lowest: compounds 3 and 2 (each within the scatter of the next); then compound 1. At a limit, above all of these: compound 4.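

In this assay compound 4 stands at a limit of the assay and not at a number: the limit of > 30000 nM in this assay, at which 1 of the 4 values shown sits.

The earlier compounds shown here showed only modest gains on filling this position, but this change gives an at least 830-fold higher number from compound 3 to compound 4 (2.92 log units; beyond the scatter) and an at least 600-fold higher number from compound 2 to compound 4 (2.77 log units; beyond the scatter), so the position accepts ethyl and trifluoromethoxy without accepting every group placed there. Even against hydrogen the result is an at least 180-fold higher number from compound 1 to compound 4 (2.26 log units; beyond the scatter), which means that methylcarbamoyl does more than forfeit the gains seen with the other two groups, and a substituent at this position can cost far more than the earlier steps gained.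

The compounds shown leave open whether the loss goes with the amide hydrogen, the carbonyl or the methylcarbamoyl group as a whole, a question that a dimethylcarbamoyl group, which has no amide hydrogen, or an acetyl group, which keeps the carbonyl, would help to separate. They also leave open how a simple amine or a carboxylic acid would read at this same position on the shared core.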